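This account rests on a few compounds, and the source may have more. Where it says the series, first, only, none or still open, it means among the compounds named here.

Compound 1 `Cc1ccc2nc(/N=C3\C(=O)N(CN(C)C)c4ccccc43)sc2c1`: in a functional assay on MCF7 cells (Homo sapiens) for cytotoxicity, read by sulforhodamine B assay, with a stated time of 48 h (a higher number here means a weaker inhibitor of growth, a lower number a stronger inhibitor of growth), compound 1 gives 29200 nM.
Compound 2 `Cc1ccc2nc(/N=C3\C(=O)N(CN(C)C)c4cccc(Cl)c43)sc2c1`: in this assay compound 2 gives 20700 nM.
Compound 3 `CN(C)CN1C(=O)C(=O)c2ccccc21`: in this assay compound 3 gives 40500 nM.

Among the measured compounds shown here, the one change made between measured compounds is chloro in place of hydrogen on an aromatic carbon, and it gave a 1.4-fold lower number from compound 1 to compound 2 (0.15 log units; within the scatter). Compound 3 carries a smaller core than compound 1; how the two cores differ is not broken down here, and the values of compound 3 and compound 1 lie within the usual scatter of each other. Compound 4 `CN(C)CN1C(=O)C(=O)c2c(Cl)cccc21` is related to compound 3 by chloro in place of hydrogen on an aromatic carbon, the same change as that from compound 1 to compound 2, on the same kind of place. The step is expected to be about a 1.4-fold lower number from compound 3 to compound 4 (0.13 log units; within the scatter) in this assay, because the earlier step was a 1.4-fold lower number from compound 1 to compound 2 (0.15 log units; within the scatter). Compound 4 is therefore estimated at 30000 nM, expected between 15000 nM and 60000 nM.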

Compound 4, concentration for 50% growth inhibition: 87800 nM
For compound 4 the middle estimate is 2.9-fold (0.47 log units) below the measured one; the whole stated range lies below it.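

In this assay, chloro in place of hydrogen on an aromatic carbon gave a 2.2-fold higher number from compound 3 to compound 4 (0.34 log units; beyond the scatter). Set beside the earlier step, the same change did not carry over from one core to the other: the same change on two cores in this assay, a 1.4-fold lower number (0.15 log units; within the scatter) from compound 1 to compound 2 and a 2.2-fold higher number (0.34 log units; beyond the scatter) from compound 3 to compound 4, 3.1-fold (0.49 log units) apart, beyond the scatter of two such steps

This comparison rests on a single pair of steps, one of them within the scatter, so it shows only that the outcome of this change differed between these two cores, not why it differed or how any other change would carry across. As far as these compounds go, whether fluoro, bromo or a methoxy group in the same place would separate the two cores in the same way remains open. So does the outcome of chloro on the other carbons of that ring.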